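An Isopropyl Group Added to Compound 2

A few compounds are considered here, and "the series" means these few. Any claim that something is new, unique, unknown or untested is made for them only; others in the source may bear on it.

Going by the values given here, in a physicochemical assay for lipophilicity, using the shake flask method, in phosphate buffer, measured as octanol-water partition, with a stated time of 24 h, at pH 7.4, tested at 100 uM (on this read-out lower numbers stand for lower lipophilicity and higher numbers for higher lipophilicity), compound 2 (`O=C(O)CS(=O)(=O)c1ccc(OCc2cccc(-c3ccccc3)c2)cc1`) gives 2.13 as the only number available so far, so it cannot yet be ranked against any other compound. Compound 1 (`COc1cc(C)c(-c2cccc(COc3ccc4c(c3)C(=O)CC4CC(=O)O)c2)c(C)c1`) offers no comparison, since its entry in this assay reads "not determined" (no result reported) and carries no number.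

Compound 3 (`CC(C)c1ccccc1-c1cccc(COc2ccc(S(=O)(=O)CC(=O)O)cc2)c1`) has not yet been measured. It differs from compound 2 by a single change (isopropyl in place of hydrogen on an aromatic carbon), with isopropyl in place of hydrogen on an aromatic carbon of a six-membered aromatic ring of carbon only, ortho to a large group. Phenyl thereby becomes 2-isopropylphenyl.

Among the compounds with values here, no measured step between two compounds is available to size this change, so the expectation rests only on compound 2 at 2.13 and on the added isopropyl. The expected move is upward and beyond the usual scatter, estimated as a number 0.97 log units higher from compound 2 to compound 3 (beyond the scatter) in size. In this assay compound 3 is expected at an estimated 3.1 with a range from 2.6 to 3.6 on this estimate.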

Compound 3, distribution coefficient: 3.18
The estimate for compound 3 lay 0.08 log units below the measured number; measured number inside the range.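

With compound 3, this assay gains its first step between two compounds that differ in one place: isopropyl in place of hydrogen on an aromatic carbon, ortho to a large group, gives a number 1.05 log units higher from compound 2 to compound 3 (beyond the scatter) and turns phenyl into 2-isopropylphenyl. Compound 2 previously stood alone, with no other number to place it against, so nothing had shown how this read-out responds to a change at this position. The step now shows that this single substitution on the six-membered aromatic ring of carbon only is enough to carry the value past the usual scatter, though nothing presented here accounts for the size of the move.

The compounds shown leave open whether an ethyl or tert-butyl group at the same place, or an amine or a hydroxyl group, would move the value in the same direction and to a similar extent. Going by these compounds, a single step sets no trend, and whether isopropyl would give a step of this size on another carbon of that ring also remains open.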